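Hydroxamate nitrogen substitution on the shared core

The source may hold more compounds than are shown below. What is called first, only, known or untested is meant among the compounds shown, and "the series" means these compounds.

Compound 1 `CC(C)=CCCC1=CC[C@H](C(=O)N(C)O)[C@@H](c2ccccc2)C1` carries a hydroxy and a methyl on the amide nitrogen of the shared core; in an assay on isolated protein for inhibition of Apoptosis regulator Bcl-2 (Homo sapiens), read by fluorescence polarization, with stated times of 5 min and 10 min (a higher number here means a weaker inhibitor, a lower number a stronger inhibitor), compound 1 gives 2100 nM. Compound 3 `CC(C)=CCCC1=CC[C@H](C(=O)N(C)C)[C@@H](c2ccccc2)C1` carries two methyls on that nitrogen. In this assay compound 3 gives only a limit, > 23000 nM. Compound 2 `COC(=O)c1ccc(NC(=O)[C@H]2CC=C(CCC=C(C)C)C[C@@H]2c2ccccc2)cc1` replaces the amide substituents with an ester-bearing anilide. In this assay compound 2 likewise gives only a limit, > 23000 nM. Compound 3 therefore stands at the upper boundary of the numbers shown (the limit of > 23000 nM in this assay, at which 2 of the 3 values shown sit), and the only step that can be read is an at least 10-fold higher number from compound 1 to compound 3 (1.03 log units; beyond the scatter). Compound 4 `CC(C)=CCCC1=CC[C@H](C(=O)NO)[C@@H](c2ccccc2)C1` is the next to be measured; its change from compound 3 is hydroxyamino in place of dimethylamino on a carbonyl carbon. This change brings back the hydroxy whose loss is seen in an at least 10-fold higher number from compound 1 to compound 3 (1.03 log units; beyond the scatter), so a return toward the number of compound 1 is expected, estimated as an at least 7.6-fold lower number from compound 3 to compound 4 (0.88 log units; beyond the scatter). For compound 4 in this assay a value of about 3000 nM is estimated, with a range from 800 nM to 15000 nM.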

Compound 4, inhibition constant: 600 nM
Compound 4: the middle estimate sits 5.0-fold (0.70 log units) above what was measured; the measured number lies below the stated range.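

In this assay, hydroxyamino in place of dimethylamino on the carbonyl carbon gives an at least 38-fold lower number from compound 3 to compound 4 (1.58 log units; beyond the scatter), and hydroxy in place of 4-(methoxycarbonyl)phenyl on the amide-type nitrogen gives an at least 38-fold lower number from compound 2 to compound 4 (1.58 log units; beyond the scatter). Both steps start from a limit of the assay, not a number: the limit of > 23000 nM in this assay, at which 2 of the 4 values shown sit. With the hydroxy kept, hydrogen in place of methyl on that nitrogen gives a 3.5-fold lower number from compound 1 to compound 4 (0.54 log units; beyond the scatter), so the methyl is not needed for binding in this pair, and the series gains from its removal, not merely holds.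

Still open, from the compounds shown here alone, is whether a carboxylic acid in place of the hydroxyamino group on the carbonyl carbon would keep a number near that of compound 4. Also open, going by these compounds, is how a longer chain than methyl on the nitrogen carrying the hydroxy would read.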